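Methoxy for Methyl on the Aryl Ring of Compound 3

The source may hold more compounds than are shown below. What is called first, only, known or untested is meant among the compounds shown, and "the series" means these compounds.

Compound 1 `CCOC(=O)C1=Cc2ccccc2OC1(OCc1cc(-c2ccc(C)cc2)no1)C(F)(F)F`: in a functional assay on MCF7 cells (Homo sapiens) for inhibition, read by MTT assay, with a stated time of 24 h (on this read-out higher numbers stand for weaker inhibition and lower numbers for stronger inhibition), compound 1 reaches only the assay limit of > 150000 nM.
Compound 2 `CCOC(=O)C1=Cc2ccccc2OC1(OCc1cn(CC(=O)NC2CCCCC2)nn1)C(F)(F)F`: in this assay compound 2 gives 12100 nM.
Compound 3 `Cc1ccc(-c2cc(COC3(C(F)(F)F)Oc4ccccc4C=C3C(=O)O)on2)cc1`: in this assay compound 3 gives 30100 nM.

Among the two numbers actually reached, compound 3 stands highest; compound 2 gives the lower number, and that gap lies beyond the usual scatter. Going by the values given here, the only single-place step among the measured compounds is an at least 4.9-fold lower number from compound 1 to compound 3 (0.69 log units; beyond the scatter), and it starts from a value that is itself a limit, (the limit of > 150000 nM in this assay, at which 1 of the 3 values shown sits), so its true size is not known beyond being at least modest.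

The next compound, compound 4 `COc1ccc(-c2cc(COC3(C(F)(F)F)Oc4ccccc4C=C3C(=O)O)on2)cc1`, is built from compound 3 by a change elsewhere: methoxy in place of methyl on an aromatic carbon. Among the compounds with values here, no measured step touches this position; the one step that is known concerns the ester-to-acid change at the carbonyl, not the aryl substituent. Within the data shown here, nothing among the measured compounds therefore gives a direction for this change, and the step is expected to stay within the scatter: a 1.0-fold lower number from compound 3 to compound 4 (0.00 log units; within the scatter). On that basis compound 4 is estimated at 30000 nM, with a range from 10000 nM to 90000 nM.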

Compound 4, half-maximal inhibitory concentration: 35200 nM
The estimate for compound 4 lay 1.2-fold (0.07 log units) below the measured number; low and high end bracket the measured number.
By their numbers in this assay, from the lowest: compound 2; then compounds 3 and 4 (each within the scatter of the next). At a limit, above all of these: compound 1.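

In this assay, going by these compounds alone, methoxy in place of methyl on this aromatic carbon, para to a large group, gives a 1.2-fold higher number from compound 3 to compound 4 (0.07 log units; within the scatter), the first measured step at this position. Going from 4-methylphenyl to 4-methoxyphenyl adds one heavy atom and one hydrogen-bond acceptor, yet compound 3 and compound 4 cannot be told apart in this assay, so within this pair the change leaves the read-out inside the scatter. Nothing measured among the compounds shown bears on why this step stays so small, and no reason can be given for it.

Only methyl and methoxy are shown at this position, so it stays open whether an amine, a chlorine atom or a longer chain such as butoxy would shift the number beyond the scatter. From the compounds shown here alone, it also stays open whether the change from the ethyl ester to the carboxylic acid, known here only with 4-methylphenyl and from a start at an assay limit, would look the same with 4-methoxyphenyl in place.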